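Fluorinated benzamide variant of an inactive piperidine pair

This account rests on a few compounds, and the source may have more. Where it says the series, first, only, none or still open, it means among the compounds named here.

Compound 1 `CCOC(=O)N1CCC(N2CCC[C@@H](NC(=O)c3ccc(C)cc3)C2)CC1`: in a functional assay on CHO cells for agonist activity at muscarinic acetylcholine receptor M5 (Rattus norvegicus) (a lower number here means that less compound is needed, a higher number that more compound is needed for the effect), compound 1 gives > 10000 nM, which is a limit of the assay.
Compound 2 `CCOC(=O)N1CCC(NCCNC(=O)c2ccccc2C)CC1`: in this assay compound 2 gives > 30000 nM, also a limit.

Compound 1 therefore stands only at a limit, and the same holds for compound 2 (the limit of > 10000 nM in this assay, at which 1 of the 2 values shown sits, (the limit of > 30000 nM in this assay, at which 1 of the 2 values shown sits)). Compound 3 `CCOC(=O)N1CCC(N2CCC[C@@H](NC(=O)c3ccc(F)cc3C)C2)CC1` differs from compound 1 by 4-fluoro-2-methylphenyl in place of 4-methylphenyl on a carbonyl carbon. For the measured compounds named here, no measured step exists between these compounds. The step from compound 1 to compound 3 in this assay is expected to be a step that the limit leaves unreadable from compound 1 to compound 3, nothing beyond the scatter. Compound 3 is estimated at 20000 nM, between 5000 nM and 100000 nM, most likely again only a limit.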

Compound 3, half-maximal effective concentration: > 10000 nM
Compound 3: no number, only a limit; the forecaster's own chance of this, stated with the estimate: 80%; the middle value does not contradict the limit.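

In this assay, compound 1 and compound 3 both stand at the same limit, so no step can be read between them: the limit of > 10000 nM in this assay, at which 2 of the 3 values shown sit.

The compounds shown leave open whether 4-fluoro-2-methylphenyl in place of 4-methylphenyl changes the half-maximal effective concentration at all, since none of them gives an actual number.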